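From compound 2 to compound 4: adding a chloro group

The source may report more compounds than this note shows. Statements on the series, on what has been measured and on what is new or still open speak of the compounds shown alone.

Compound 1 `O=C1/C(=C/c2cccc([N+](=O)[O-])c2)CCCc2ccccc21` gives 8820 nM
Compound 2 `O=C1CCCCC/C1=C\c1ccccc1` gives 215000 nM
Compound 3 `O=C1CCCCC/C1=C\c1ccc(F)cc1` gives 250000 nM

In a functional assay on MOLT-4 cells (Homo sapiens) for inhibition (on this read-out lower numbers stand for stronger inhibition and higher numbers for weaker inhibition), compound 2 (215000 nM) lies within the scatter of compound 3 (250000 nM), and both numbers lie well above that of compound 1 (8820 nM). Compound 4 (`O=C1CCCCC/C1=C\c1cccc(Cl)c1`) has not been measured yet. It differs from compound 2 in one place (chloro in place of hydrogen on an aromatic carbon), with chloro in place of hydrogen on an aromatic carbon.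

Among the compounds with values here, only one measured step is of a similar kind, fluoro in place of hydrogen on an aromatic carbon (a 1.2-fold higher number from compound 2 to compound 3 (0.07 log units; within the scatter)), and it stays within the scatter. Compound 1 differs from compound 2 in more than one place, so it offers no clean comparison. One small step with a different atom is thin evidence, but a change beyond the scatter in this assay is not expected. The expected step is small (a 1.3-fold lower number from compound 2 to compound 4 (0.10 log units; within the scatter)), and its direction remains uncertain. For compound 4 the estimated value is (170000 nM), with an expected range of (70000 nM to 320000 nM).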

Compound 4, half-maximal inhibitory concentration: 88600 nM
Compound 4: middle estimate off by 1.9-fold (0.28 log units), on the high side; the range from low to high includes it.
By their numbers in this assay, from the lowest: compound 1; then compound 4; then compounds 2 and 3 (each within the scatter of the next).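

In this assay, a single chloro group on an aromatic carbon, meta to a group of 9 heavy atoms, moves the number beyond the scatter (a 2.4-fold lower number from compound 2 to compound 4 (0.39 log units; beyond the scatter)). The earlier fluoro step (a 1.2-fold higher number from compound 2 to compound 3 (0.07 log units; within the scatter)) stayed within the scatter, so the aromatic ring of compound 2 does not respond alike to every replacement of a hydrogen, although this new step is only modest. Nothing available here explains the step.

As far as these compounds go, what an amine, a methoxy group or a carboxylic acid would do at this same place remains open, and only such groups could show whether the chloro result extends beyond one atom. Also open, from the compounds shown here alone, is whether chloro would give a similar step on the core of compound 1.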